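Trimethoxyphenyl step from compound 2 to compound 3

This account rests on a few compounds, and the source may have more. Where it says the series, first, only, none or still open, it means among the compounds named here.

In a functional assay on MCF7 cells (Homo sapiens) for inhibition, read by MTT assay, with a stated time of 48 h (on this read-out lower numbers stand for stronger inhibition of growth and higher numbers for weaker inhibition of growth), compound 1 `COc1ccc2c(c1)c(C1CC(c3ccc(Cl)cc3)=NN1C(=O)c1ccc(OC)nc1)cn2C` gives 3710 nM as its reading. Within the data shown here, compound 2 `COc1ccc(C2=NN(C(=O)c3ccc(OC)nc3)C(c3cn(C)c4ccc(OC)cc34)C2)cc1` gives 560 nM and holds the lower of the two numbers so far. The next change leads to compound 3 `COc1ccc2c(c1)c(C1CC(c3cc(OC)c(OC)c(OC)c3)=NN1C(=O)c1ccc(OC)nc1)cn2C` and puts 3,4,5-trimethoxyphenyl in place of 4-methoxyphenyl on a carbon with a double bond to nitrogen while the rest of the structure stays the same. Among the measured compounds shown here, only one measured step bears on this: the move of a 6.6-fold lower number from compound 1 to compound 2 (0.82 log units; beyond the scatter) is modest but beyond the scatter, with methoxy in place of chloro on the same substituent. For the measured compounds named here, that single step shows that this substituent can shift the number, but no measured compound carries the 3,4,5-trimethoxyphenyl group. In this assay a small move toward a lower number is therefore expected, perhaps none beyond the scatter, and the expected step is a 1.4-fold lower number from compound 2 to compound 3 (0.15 log units; within the scatter) on this estimate. For compound 3 the estimated value is 400 nM with an expected range of 100 nM to 1500 nM on present evidence.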

Compound 3, concentration for 50% growth inhibition: > 10000 nM
Compound 3 gave a limit, no number; the forecaster's own chance of this, stated with the estimate: 3%; middle value at least 25-fold (1.39 log units) away from the limit.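

In this assay compound 3 stands at a limit of the assay and not at a number: the limit of > 10000 nM in this assay, at which 1 of the 3 values shown sits.

Until now the substituent on the carbon with a double bond to nitrogen had shown only a modest move, and the richer methoxy pattern turns that into a large one: 3,4,5-trimethoxyphenyl in place of 4-methoxyphenyl gives an at least 17-fold higher number from compound 2 to compound 3 (1.25 log units; beyond the scatter). The same group also falls behind the 4-chlorophenyl group, with an at least 2.6-fold higher number from compound 1 to compound 3 (0.43 log units; beyond the scatter), so at this position it ranks below both earlier aryl groups and the step to methoxy seen earlier does not extend to more methoxy groups on the same ring. Among the three compounds, the 4-methoxyphenyl group of compound 2 gives the lowest number, and adding methoxy groups to that ring does not carry the gain further.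

The compounds shown do not tell which of the added methoxy groups carries the loss, and a dimethoxyphenyl group would bear on that. From the compounds shown here alone, how this position responds to a group of another kind on the ring, such as an amine or a carboxylic acid, also stays open.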